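Sulfonamide aryl swap on a nicotinamide phosphoribosyltransferase inhibitor

The source may hold more compounds than are shown below. What is called first, only, known or untested is meant among the compounds shown, and "the series" means these compounds.

Measured compounds:
compound 1, `Cc1ccccc1NS(=O)(=O)c1cccc(CCCCCCNC(=O)/C=C/c2cccnc2)c1`, 5.08 nM
compound 2, `Cc1cccc(NS(=O)(=O)c2cccc(CCCCCCNC(=O)/C=C/c3cccnc3)c2)c1`, 12.3 nM
compound 3, `CC(C)(C)c1ccc(NS(=O)(=O)c2cccc(CCCCCCNC(=O)/C=C/c3cccnc3)c2)cc1`, 9.47 nM

In an assay on isolated protein for inhibition of Nicotinamide phosphoribosyltransferase (Homo sapiens), read by WST assay, with stated times of 60 min, 5 min and 30 min, in the presence of a further agent that is not named here (a lower number here means a stronger inhibitor, a higher number a weaker inhibitor), compound 3 gives 9.47 nM, the second highest number of the three; compound 2 sits nearest, and its difference from compound 3 lies within the scatter, while compound 1 lies a little further off but still within the scatter of compound 3. Compound 4, `O=C(/C=C/c1cccnc1)NCCCCCCc1cccc(S(=O)(=O)Nc2ccc(F)c(Cl)c2)c1`, has not been measured; it differs from compound 3 by 3-chloro-4-fluorophenyl in place of 4-(tert-butyl)phenyl on a sulfonamide nitrogen. The steps seen so far all change the aryl group on the sulfonamide nitrogen: a 2.4-fold higher number from compound 1 to compound 2 (0.38 log units; beyond the scatter), a 1.9-fold higher number from compound 1 to compound 3 (0.27 log units; within the scatter) and a 1.3-fold lower number from compound 2 to compound 3 (0.11 log units; within the scatter). These are modest or within the scatter, so a further exchange of the same aryl group is expected to move this assay little, with no clear direction. Compound 4 is therefore estimated at 8.5 nM, between 3 nM and 25 nM, a step of a 1.1-fold lower number from compound 3 to compound 4 (0.05 log units; within the scatter) that is expected to stay within the scatter.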

Compound 4, half-maximal inhibitory concentration: 9.7 nM
Estimate against measurement, compound 4: 1.1-fold (0.06 log units) below, within the range that was stated.
By their numbers in this assay, from the lowest: compounds 1, 3, 4 and 2 (each within the scatter of the next, the first and the last beyond it).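

In this assay, within the data shown here, the first aryl group on the sulfonamide nitrogen to carry halogens, 3-chloro-4-fluorophenyl, replaces the all-carbon 4-(tert-butyl)phenyl with a 1.0-fold higher number from compound 3 to compound 4 (0.01 log units; within the scatter), so halogen substituents fit at this position as well as the alkyl groups of the earlier compounds. The comparisons with the two methylphenyl compounds give a 1.3-fold lower number from compound 2 to compound 4 (0.10 log units; within the scatter) and a 1.9-fold higher number from compound 1 to compound 4 (0.28 log units; within the scatter), both also within the scatter. Nothing available here bears on why this exchange leaves the number so nearly unchanged.

Going by these compounds, it remains open whether an aryl group bearing a carboxylic acid or an amine, or a cyclohexyl group in place of the aryl ring, would hold the same level on this nitrogen. The compounds shown also leave open whether a longer chain in the shared core would change these numbers.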